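The compounds below may be only part of what the source reports. "The series", "measured", "known", "first", "only" and "open" are said of these compounds alone.

Measured so far in a functional assay on A-431 cells (Homo sapiens) for antiproliferative activity, read by MTT assay, with a stated time of 48 h; a higher number here means a weaker inhibitor, a lower number a stronger inhibitor:
compound 1 (`C#Cc1cccc(NC(=O)c2cc(NC(=O)CCCCCC(=O)NO)ccc2O)c1`) gives 5750 nM
compound 2 (`C#Cc1cccc(NC(=O)c2cc(NC(=O)CCCCCCC(=O)NO)ccc2O)c1`) gives 6110 nM
compound 3 (`C#Cc1cccc(NC(=O)c2cc(NC(=O)CCCCCC(=O)NO)c(OC)cc2O)c1`) gives 4680 nM

Compound 1 stands within the scatter of both other compounds (a 1.1-fold higher number from compound 1 to compound 2 (0.03 log units; within the scatter)) (a 1.2-fold lower number from compound 1 to compound 3 (0.09 log units; within the scatter)), so the three numbers form one group.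

Compound 4 (`C#Cc1cccc(NC(=O)c2cc(NC(=O)CCCCCC(=O)NO)ccc2OC)c1`) is compound 1 with hydroxy changed to methoxy (methyl in place of hydrogen on an oxygen on an aromatic ring). Going by the values given here, no measured step touches this oxygen. The closest evidence is the methoxy placed on an aromatic carbon (a 1.2-fold lower number from compound 1 to compound 3 (0.09 log units; within the scatter)), a change that leaves the hydroxy in place, so it offers only weak guidance. No step beyond the scatter is expected in this assay, and no firm direction is expected either (a 1.0-fold lower number from compound 1 to compound 4 (0.02 log units; within the scatter)). For compound 4 the expected value is 5500 nM (estimated range 2500 nM to 12000 nM).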

Compound 4, half-maximal inhibitory concentration: 4200 nM
The estimate for compound 4 lay 1.3-fold (0.12 log units) above the measured number; measured number inside the range.
By their numbers in this assay, from the lowest: compounds 4, 3, 1 and 2 (each within the scatter of the next).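

In this assay, methyl in place of hydrogen on an oxygen on an aromatic ring gives a 1.4-fold lower number from compound 1 to compound 4 (0.14 log units; within the scatter). Going by these compounds alone, this is the first step at this oxygen itself, and it shows that the hydrogen of the hydroxy can be replaced by methyl without a step beyond the scatter. No measurement on hand accounts for this result.

As far as these compounds go, whether a larger group on this oxygen, such as ethyl or benzyl, would also stay within the scatter remains open. So does the outcome of an amine or a fluorine in place of the hydroxy.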